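Working notes: propoxy to butylamino on the shared core

A few compounds are considered here, and "the series" means these few. Any claim that something is new, unique, unknown or untested is made for them only; others in the source may bear on it.

Measured in an ADME assay on LL24 cells (Homo sapiens) for inhibition, read by MTT assay, with a stated time of 24 h (a higher number here means a weaker inhibitor, a lower number a stronger inhibitor), as follows
Compound 1 `CC(C)c1ccc(C(=O)N/N=C/c2ccc([N+](=O)[O-])o2)cc1` gives the limit > 200000 nM
Compound 2 `CCCCc1ccc(C(=O)N/N=C/c2ccc([N+](=O)[O-])o2)cc1` gives the limit > 200000 nM
Compound 3 `CCCOc1ccc(C(=O)N/N=C/c2ccc([N+](=O)[O-])o2)cc1` gives the limit > 200000 nM

Compound 3 has no number in this assay and stands only at the limit > 200000 nM in this series. The three compounds share the limit of > 200000 nM in this assay, at which 3 of the 3 values shown sit, and no order among them can be read.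

Compound 4 `CCCCNc1ccc(C(=O)N/N=C/c2ccc([N+](=O)[O-])o2)cc1` differs from compound 3 by butylamino in place of propoxy on an aromatic carbon and the change sits on an aromatic carbon of a six-membered aromatic ring of carbon only, para to a large group. The measured steps that bear on it are a step that the two limits leave unreadable from compound 1 to compound 3 and a step that the two limits leave unreadable from compound 2 to compound 3 and neither has a readable size. Going by the values given here, no measured compound carries butylamino. Among the compounds with values here, no step of defined size or direction is therefore expected in this assay and a further limit is the likeliest report. The estimated change is a number no higher from compound 3 to compound 4 (the limit leaves the size open) on this expectation. The expected value for compound 4 is 200000 nM with an estimated range from 70000 nM to 400000 nM in this assay.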

Compound 4, half-maximal inhibitory concentration: 47000 nM
For compound 4 the middle estimate is 4.3-fold (0.63 log units) above the measured one, and the stated range ends above it.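

In this assay, the aromatic carbon para to a large group responds to a change of substituent: butylamino in place of propoxy gives an at least 4.2-fold lower number from compound 3 to compound 4 (0.62 log units; beyond the scatter), butylamino in place of butyl gives an at least 4.2-fold lower number from compound 2 to compound 4 (0.62 log units; beyond the scatter), and butylamino in place of isopropyl gives an at least 4.2-fold lower number from compound 1 to compound 4 (0.62 log units; beyond the scatter). Going by these compounds alone, the steps among compound 1, compound 2 and compound 3 cannot be read, and these are the first steps at this position with a readable direction. Compound 4 alone among the compounds shown stands off the shared limit: the limit of > 200000 nM in this assay, at which 3 of the 4 values shown sit.

Going by these compounds, the full size of each step stays open, as each has a limit at one end. Also open, on these data alone, is whether the change follows the nitrogen or the chain, a question that butoxy or propylamino at the same position would address.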